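Side-chain amide in place of the diamine: compound 4

A few compounds are considered here, and "the series" means these few. Any claim that something is new, unique, unknown or untested is made for them only; others in the source may bear on it.

Three compounds of the series carry a measurement in an assay on isolated protein (urine) for inhibition of Myeloperoxidase (Homo sapiens), with a stated time of 5 min; a higher number here means a weaker inhibitor, a lower number a stronger inhibitor. For the measured compounds named here, compound 2 `NCC(N)CCc1c[nH]c2ccc(F)cc12` gives 60 nM and is the only entry with a number. Compound 1 `NCCCCc1c[nH]c2ccc(C(=O)O)cc12` is reported in this assay as "not active" (no number reported). Compound 3 `NCCSCCCc1c[nH]c2c(F)cccc12` is reported in this assay only at a limit, > 100 nM, which is not a number but the edge of the measurement; this is the limit of > 100 nM in this assay, at which 1 of the 3 values shown sits. No two measured compounds differ in one place, so no measured step exists, and nothing in the three values points to a cause for their spread.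

Compound 4 `CCNC(=O)CCCc1c[nH]c2ccc(F)cc12` is not yet measured. Its difference from compound 2 is (ethylcarbamoyl)methyl in place of 1,2-diaminoethyl on a saturated chain carbon, two bonds along the chain from an aromatic carbon. The change sits on a saturated chain carbon, two bonds along the chain from an aromatic carbon, and trades two hydrogen-bond donors and two acceptors for one of each.

Because compound 2 gives 60 nM while compound 1 and compound 3 give no number, the step from compound 2 to compound 4 is expected to lie beyond the scatter toward weaker inhibition, a 10-fold higher number from compound 2 to compound 4 (1.00 log units; beyond the scatter). Compound 4 is estimated at 600 nM in this assay, with a range from 120 nM to 3000 nM, and a real chance that only a limit is returned.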

Compound 4, half-maximal inhibitory concentration: 182 nM
Compound 4: the middle estimate sits 3.3-fold (0.52 log units) above what was measured; the range from low to high includes it.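

In this assay, for the compounds shown here, (ethylcarbamoyl)methyl in place of 1,2-diaminoethyl on a saturated chain carbon, two bonds along the chain from an aromatic carbon, gives a 3.0-fold higher number from compound 2 to compound 4 (0.48 log units; beyond the scatter), the first step that can be read. The step is modest, and compound 4 still returns a number, 182 nM, so within this pair inhibition with a numerical reading does not depend on the 1,2-diaminoethyl group, although compound 4 is the weaker of the two. Compound 3 remains a limit and not a number, and compound 1 has no number, so no step to either can be read: the limit of > 100 nM in this assay, at which 1 of the 4 values shown sits.

Going by these compounds alone, the single step exchanges the whole 1,2-diaminoethyl group for the amide-bearing (ethylcarbamoyl)methyl group, and it does not separate the contribution of the amines from that of the carbonyl, the amide hydrogen or the ethyl group. On these data alone, whether a methyl amide or a carboxylic acid at the end of the chain, on the core of compound 2, would read closer to compound 2 or to compound 4 remains open.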